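The source may report more compounds than this note shows. Statements on the series, on what has been measured and on what is new or still open speak of the compounds shown alone.

In an ADME assay on HepG2 cells (Homo sapiens) for cytotoxicity (on this read-out higher numbers stand for an effect only at larger amounts of compound and lower numbers for an effect already at smaller amounts), three compounds sharing one core have been measured. Compound 1 (`Cc1ccc(S(=O)(=O)N[C@@H](CC(=O)NC(C)(C)C)C(=O)NCCNC(=O)c2cc(Cl)ccn2)cc1`) gives > 11000 nM, which is a limit of the assay and not a number. Compound 2 (`Cc1ccc(S(=O)(=O)N[C@@H](CC(=O)NC(C)(C)C)C(=O)NCCNC(=O)Nc2ccccc2)cc1`) gives > 11000 nM, which is also only a limit. Compound 3 (`Cc1ccc(S(=O)(=O)N[C@@H](CC(=O)NC(C)(C)C)C(=O)NCCNC(=O)c2ccc(F)cc2)cc1`) gives > 11000 nM, again a limit, so its standing is known no more exactly than that.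

Compound 4 (`Cc1ccc(S(=O)(=O)N[C@@H](CC(=O)NC(C)(C)C)C(=O)NCCNC(=O)NCc2ccccc2)cc1`) carries benzylamino in place of 4-fluorophenyl on a carbonyl carbon. Among the compounds with values here, three measured steps concern this same carbonyl carbon. The closest is a step that the two limits leave unreadable from compound 2 to compound 3, as it joins anilino and 4-fluorophenyl. The other two are a step that the two limits leave unreadable from compound 1 to compound 2 and a step that the two limits leave unreadable from compound 1 to compound 3. None of them has a readable size, and the series offers only this: the limit of > 11000 nM in this assay, at which 3 of the 3 values shown sit.

The expectation therefore rests on compound 2, whose anilino group is the nearest relative of benzylamino and whose reading is the limit > 11000 nM. No step beyond the scatter is expected in this assay, and no direction can be assigned to it. The expected step is a step that the limit leaves unreadable from compound 3 to compound 4. Compound 4 will most likely be reported as a limit too, and as a number it is estimated at 16000 nM, with an expected range from 8000 nM to 35000 nM.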

Compound 4, half-maximal effective concentration: > 11000 nM
Compound 4 gave a limit, no number (the forecaster's own chance of this, stated with the estimate: 85%); the middle value lies beyond the limit too.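

In this assay compound 4 is reported only as a limit, like compound 1, compound 2 and compound 3, so none of its steps to those compounds can be read. All that the series shows is this: the limit of > 11000 nM in this assay, at which 4 of the 4 values shown sit.

The compounds shown leave open where any of the four would actually take effect, and whether the groups on this carbonyl carbon differ at all.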